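The source may report more compounds than this note shows. Statements on the series, on what has been measured and on what is new or still open speak of the compounds shown alone.

Measured compounds:
compound 1 `COC(=O)c1cc2cc(NCc3cc(NC(=O)c4cncc(C(F)(F)F)c4)ccc3C)cnc2[nH]1`: 390 nM
compound 2 `COC(=O)c1cc2cc(NCc3cc(NC(=O)c4ccc(CN5CCC(N(C)C)C5)c(C(F)(F)F)c4)ccc3C)cnc2[nH]1`: 689 nM

Both were tested in a functional assay on HUVEC cells (Homo sapiens), read by MTT assay, with a stated time of 72 h; a lower number here means that less compound is needed, a higher number that more compound is needed for the effect. Compound 1 gives 390 nM, and compound 2 gives 689 nM; the two values lie within the scatter of each other, so compound 2 stands level with compound 1 in this pair. Compound 3 `CC(=O)c1cc2cc(NCc3cc(NC(=O)c4ccc(CN5CCC(N(C)C)C5)c(C(F)(F)F)c4)ccc3C)cnc2[nH]1` has not yet been measured in this assay. It differs from compound 2 in one place: methyl in place of methoxy on a carbonyl carbon. Among the measured compounds shown here, no step between two measured compounds reports what this change does, so its direction cannot be read from the data at hand. Because compound 2 gives 689 nM and the remainder of the structure is unchanged, the number for compound 3 is expected to stay close, with a 1.0-fold higher number from compound 2 to compound 3 (0.01 log units; within the scatter) estimated as a step of no size beyond the scatter. Compound 3 is estimated at 700 nM, with a range of 250 nM to 2000 nM.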

Compound 3, half-maximal effective concentration: 97 nM
Compound 3: middle estimate off by 7.2-fold (0.86 log units), on the high side; measured number outside the range, below it.
By their numbers in this assay, from the lowest: compound 3; then compounds 1 and 2 (each within the scatter of the next).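

The group on this carbonyl carbon turns out not to be a silent feature of the molecule. Among the compounds shown here, with the rest of the structure unchanged, methyl in place of methoxy gives a 7.1-fold lower number from compound 2 to compound 3 (0.85 log units; beyond the scatter) in this assay, the first change at this position that can be read on its own, as compound 1 and compound 2 differ elsewhere. The data shown offer nothing that accounts for the size of this step, which rests on a single pair of compounds.

The compounds shown leave open whether an ethyl group or an amine on the same carbonyl carbon would take the number further down or back up. They also leave open whether the methoxycarbonyl to acetyl exchange would act the same way with the amide part of compound 1.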